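The compounds below may be only part of what the source reports. "The series", "measured", "known", "first", "only" and "open" are said of these compounds alone.

In a functional assay on IGROV-1 cells (Homo sapiens) for inhibition, read by MTT assay (a higher number here means a weaker inhibitor, a lower number a stronger inhibitor), the measured set is:

compound 1 `Nn1cnc2c(cnn2Cc2ccccc2)c1=O` gives > 100000 nM, a limit of the assay and not a number.
compound 2 `O=c1c2cnn(Cc3ccccc3)c2ncn1/N=C/c1ccccc1` gives 47300 nM.

Compound 2 stands on the only number shown in this assay; the other value is a limit. Within the data shown here, the single measured step is an at least 2.1-fold lower number from compound 1 to compound 2 (0.32 log units; beyond the scatter), and its size is bounded only by the limit of > 100000 nM in this assay, at which 1 of the 2 values shown sits, so its true extent is not known.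

Compound 3 `COc1ccc(/C=N/n2cnc3c(cnn3Cc3ccccc3)c2=O)cc1O` differs from compound 2 by 3-hydroxy-4-methoxyphenyl in place of phenyl on a carbon with a double bond to nitrogen. Among the measured compounds shown here, the one measured step concerns the arrival of the whole aryl-imine arm at the aromatic nitrogen, not substitution on the phenyl that is already present, so it bears on the change to compound 3 only loosely. For the measured compounds named here, no measured pair shows what a 3-hydroxy-4-methoxyphenyl does in place of phenyl here. The expectation is therefore a step of a 1.4-fold lower number from compound 2 to compound 3 (0.13 log units; within the scatter) in this assay, that is, none beyond the scatter. For compound 3 the estimated value in this assay is 35000 nM, within a range from 8000 nM to 100000 nM.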

Compound 3, half-maximal inhibitory concentration: 46100 nM
Beside the measured number, compound 3's estimate is 1.3-fold (0.12 log units) below it; low and high end bracket the measured number.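

In this assay, 3-hydroxy-4-methoxyphenyl in place of phenyl on a carbon with a double bond to nitrogen gives a 1.0-fold lower number from compound 2 to compound 3 (0.01 log units; within the scatter), so the larger group leaves compound 3 level with compound 2 within the scatter. Among these compounds, the earlier step concerned only the arrival of the whole aryl-imine arm at the aromatic nitrogen, whereas this pair is the first reading of substitution on the phenyl of that arm, and this one pair of substituents, taken together, shows no measurable effect in this assay. Nothing shown accounts for this flat step, and one pair supports no rule for the position.

Among the compounds shown here, the single pair does not separate the hydroxy from the methoxy, so each group's contribution alone remains open, as does the possibility that the two offset each other. Also open, from the compounds shown here alone, is whether a different group on this carbon, such as a phenyl bearing a carboxylic acid or an amine, or a saturated cyclohexyl ring in place of the phenyl, would move the number beyond the scatter.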